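The source may report more compounds than this note shows. Statements on the series, on what has been measured and on what is new or still open speak of the compounds shown alone.

Compound 1 `Cc1ccc([S+]([O-])N2CCC[C@H]2COCCCCCC/C=C/c2ccc(-c3ccccc3)cc2)cc1` and compound 2 `Cc1ccc([S+]([O-])N2CCC[C@H]2COCCCCCC/C=C/c2ccc(Oc3ccccc3)cc2)cc1` share one core, while compound 3 `O=CN1CCC[C@H]1COCCCCCC/C=C/c1ccc(-c2ccccc2)cc1` carries a different one; the two cores differ in this way: a group of 2 heavy atoms (1 carbon, 1 oxygen; no ring) in place of a group of 9 heavy atoms (7 carbon, 1 oxygen, 1 sulfur; one six-membered aromatic ring of carbon only), on an amine nitrogen in a ring. In a functional assay on PANC-1 cells (Homo sapiens) for inhibition, read by XTT assay, with a stated time of 72 h (a higher number here means a weaker inhibitor, a lower number a stronger inhibitor), compound 1 gives only a limit of the assay, >= 100000 nM. Compound 2 gives 60000 nM in this assay, and compound 3 gives 50000 nM in this assay. The change phenoxy in place of phenyl on an aromatic carbon made an at least 1.6-fold lower number from compound 1 to compound 2 (0.22 log units; that floor lies within the scatter), and the change of core made an at least 2.0-fold lower number from compound 1 to compound 3 (0.30 log units; that floor lies within the scatter). Compound 4 `O=CN1CCC[C@H]1COCCCCCC/C=C/c1ccc(Oc2ccccc2)cc1` is not yet measured. It differs from compound 3 by phenoxy in place of phenyl on an aromatic carbon, at the same place as before, so this is the same change. In this assay the expected step is a 1.4-fold lower number from compound 3 to compound 4 (0.15 log units; within the scatter), resting on the earlier step of an at least 1.6-fold lower number from compound 1 to compound 2 (0.22 log units; that floor lies within the scatter) whose floor lies within the scatter, so little movement is expected. Compound 4 is therefore estimated at 35000 nM, expected between 12000 nM and 100000 nM.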

Compound 4, half-maximal inhibitory concentration: 53300 nM
Beside the measured number, compound 4's estimate is 1.5-fold (0.18 log units) below it, within the range that was stated.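

In this assay, phenoxy in place of phenyl gives a 1.1-fold higher number from compound 3 to compound 4 (0.03 log units; within the scatter), and the change of core gives a 1.1-fold lower number from compound 2 to compound 4 (0.05 log units; within the scatter), so on these compounds neither change moves the number beyond the usual scatter. This does not show whether the phenoxy change behaves alike on both cores: the same change on two cores in this assay, an at least 1.6-fold lower number (0.22 log units; that floor lies within the scatter) from compound 1 to compound 2 and a 1.1-fold higher number (0.03 log units; within the scatter) from compound 3 to compound 4; the limit leaves it open whether they differ The change of core stays just as open, since compound 1 gives only a limit of the assay: the same change on two cores in this assay, an at least 2.0-fold lower number (0.30 log units; that floor lies within the scatter) from compound 1 to compound 3 and a 1.1-fold lower number (0.05 log units; within the scatter) from compound 2 to compound 4; the limit leaves it open whether they differ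

The compounds shown leave open what a different group in place of phenyl or phenoxy, such as an amine or a carboxylic acid, would do. They also leave open what a shorter or longer chain would do.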